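The source may hold more compounds than are shown below. What is called first, only, known or untested is meant among the compounds shown, and "the series" means these compounds.

Compound 1 `C=CC(=O)N[C@H]1CCN(S(=O)(=O)c2ccc(NC(=O)OCc3ccccc3)cc2)C1`: > 6 h
Compound 2 `C=CC(=O)N[C@@H]1CCN(S(=O)(=O)c2ccc(NC(=O)OCc3ccccc3)cc2)C1`: > 6 h
Compound 3 `C=CC(=O)NC1CCN(S(=O)(=O)c2ccc(C(=O)NCc3ccccc3)cc2)CC1`: > 6 h

All the evidence here comes from an ADME assay on a cell-free system (plasma, Mus musculus) for metabolic stability, tested at 1 uM (on this read-out higher numbers stand for a longer-lived compound and lower numbers for a shorter-lived compound), and it is thin: the limit of > 6 h in this assay, at which 3 of the 3 values shown sit. In this assay, compound 3 stands at > 6 h, which is a limit and not a number.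

Compound 4 `C=CC(=O)NC1CCN(S(=O)(=O)c2ccc(C(=O)NCc3cccc4ccccc34)cc2)CC1` departs from compound 3 by a single change: naphthalen-1-yl in place of phenyl on a saturated chain carbon bound to an amide-type nitrogen. In words, this is naphthalen-1-yl in place of phenyl on a saturated chain carbon bound to an amide-type nitrogen.

Going by the values given here, the only measured step is a step that the two limits leave unreadable from compound 1 to compound 2. It concerns a different kind of change, namely (the fact that compounds 1 and 2 differ only in the configuration as drawn), so it gives no size to carry over. Among the compounds with values here, no measured step covers the change from phenyl to naphthalen-1-yl. With nothing to suggest a direction, no shift beyond the usual scatter is expected, and compound 4 will probably also be reported only as a limit. The expected step is a step that the limit leaves unreadable from compound 3 to compound 4. Compound 4 is estimated at 7 h, with an expected range of 3.5 h to 14 h.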

Compound 4, half-life: > 6 h
Compound 4: only a limit was reported (the forecaster's own chance of this, stated with the estimate: 75%); the middle value lies beyond the limit too.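

In this assay, going by these compounds alone, compound 3 and compound 4 are both reported only as limits, and no step between them can be read. The compounds shown leave open how far each lies beyond its limit, and whether naphthalen-1-yl in place of phenyl alters the half-life at all.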